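From 4-methylbenzyl to 4-ethylphenyl on the shared core

The compounds below may be only part of what the source reports. "The series", "measured", "known", "first", "only" and "open" are said of these compounds alone.

In a functional assay on MCF7 cells (Homo sapiens) for inhibition, read by CCK-8 assay, with a stated time of 48 h (on this read-out higher numbers stand for weaker inhibition of growth and lower numbers for stronger inhibition of growth), compound 1 (`Cc1ccccc1Nc1nc(NC2CCCCC2)ncc1Cl`) gives > 100000 nM, which is a limit of the assay and not a number. Compound 2 (`Cc1ccccc1Nc1nc(Nc2ccccc2)ncc1Cl`) gives > 100000 nM, again only a limit. Going by the values given here, compound 3 (`Cc1ccc(CNc2nc(Nc3ccc(N4CCN(C)CC4)cn3)ncc2Cl)cc1`) gives 38100 nM, the only true number among the three. Compound 4 (`CCc1ccc(Nc2nc(Nc3ccc(N4CCN(C)CC4)cn3)ncc2Cl)cc1`) has not yet been measured and differs from compound 3 as follows: 4-ethylphenyl in place of 4-methylbenzyl on a nitrogen on an aromatic ring. Among the compounds with values here, the one measured step that touches a comparable place is a step that the two limits leave unreadable from compound 1 to compound 2. It puts phenyl in place of cyclohexyl, but it has no readable size, so it offers nothing to carry over to this change. No step beyond the scatter is therefore expected in this assay, and the estimated 1.3-fold lower number from compound 3 to compound 4 (0.10 log units; within the scatter) has no firm direction. The expectation stays anchored on compound 3 at 38100 nM, with a wide margin. For compound 4 the estimated value is 30000 nM, with an expected range from 8000 nM to 100000 nM.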

Compound 4, concentration for 50% growth inhibition: 8230 nM
Estimate against measurement, compound 4: 3.6-fold (0.56 log units) above; low and high end bracket the measured number.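

In this assay, a 4.6-fold lower number from compound 3 to compound 4 (0.67 log units; beyond the scatter) is the first readable step among these compounds, and it lies beyond the scatter. It shows that this place, on a nitrogen on an aromatic ring, responds to the change: 4-methylbenzyl and 4-ethylphenyl have the same count of heavy atoms, yet the number falls when the second replaces the first. The earlier step cannot be read, because compounds 1 and 2 each stand only at a limit of the assay: the limit of > 100000 nM in this assay, at which 2 of the 4 values shown sit.

The step exchanges one whole group for the other, and the compounds shown do not separate the part played by the ethyl from that of the methylene link of the benzyl. Going by these compounds, how a propyl chain or an amine in place of the ethyl would read also remains open.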